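A few compounds are considered here, and "the series" means these few. Any claim that something is new, unique, unknown or untested is made for them only; others in the source may bear on it.

Series notes. Compound 2 `COc1ccc(-c2cs/c(=N/NC(=O)CSc3nnnn3-c3ccccc3)n2-c2ccccc2)cc1` gives the lowest number of the three measured in an ADME assay on NIH3T3 cells (Mus musculus) for cytotoxicity, read by MTT assay, with a stated time of 24 h (a lower number here means a stronger inhibitor, a higher number a weaker inhibitor), at 11.7 ug/mL. Within the data shown here, compound 1 `O=C(CSc1nnnn1-c1ccccc1)N/N=c1/scc(-c2ccc(Br)cc2)n1-c1ccccc1` gives 433 ug/mL and compound 3 `Cc1nnc(SCC(=O)N/N=c2/scc(-c3ccc(Cl)cc3)n2-c2ccccc2)s1` gives 253 ug/mL; the step of a 37-fold lower number from compound 1 to compound 2 (1.57 log units; beyond the scatter) is the only single-point step among them, and compound 3 differs from compound 2 in two places, so its value is read only as a number alongside. Compound 4 `Cc1ccc(-c2cs/c(=N/NC(=O)CSc3nnnn3-c3ccccc3)n2-c2ccccc2)cc1` carries methyl in place of methoxy on an aromatic carbon. Among the measured compounds shown here, no measured pair shows methyl against methoxy, and the one large step concerns bromo against methoxy, so the expectation leans on that alone: a higher number than compound 2 in this assay, with wide uncertainty. Compound 4 is estimated at 50 ug/mL (range 10 ug/mL to 250 ug/mL), the expected step being a 4.3-fold higher number from compound 2 to compound 4 (0.63 log units; beyond the scatter).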

Compound 4, half-maximal inhibitory concentration: > 500 ug/mL
Compound 4: a limit, no number; the forecaster's own chance of this, stated with the estimate: 5%; at least 10-fold (1.00 log units) between middle value and limit.
By their numbers in this assay, from the lowest: compound 2; then compounds 3 and 1 (each within the scatter of the next). At a limit, above all of these: compound 4.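

Compound 4 gives a limit of the assay, not a number: the limit of > 500 ug/mL in this assay, at which 1 of the 4 values shown sits. In this assay, the step of an at least 42-fold higher number from compound 2 to compound 4 (1.63 log units; beyond the scatter) shows that the low number at this position does not simply follow from removing bromo: among the three groups tested here, only methoxy gives it. The step of an at least 1.1-fold higher number from compound 1 to compound 4 (0.06 log units; that floor lies within the scatter) sets no order between methyl and bromo.

On these data alone, whether the oxygen of methoxy is what matters remains open. A hydroxyl, an amine or ethoxy on this aromatic carbon would test that.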